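Replacing Methoxy with Nitro on the Top Compound

This account rests on a few compounds, and the source may have more. Where it says the series, first, only, none or still open, it means among the compounds named here.

In a functional assay on HL-60 cells (Homo sapiens) for inhibition, read by CCK-8 assay, with a stated time of 48 h, tested at 20 uM (on this read-out lower numbers stand for less inhibition of growth and higher numbers for more inhibition of growth at the one concentration tested), compound 3 (`COc1ccc(Cc2nnc(NC(=O)/C(C#N)=C/c3ccccc3OS(=O)(=O)c3ccc(OC)cc3)s2)cc1`) gives 100%, the highest of the three numbers. Compound 2 (`COc1ccc(Cc2nnc(NC(=O)/C(C#N)=C/c3ccccc3OS(=O)(=O)c3ccc(C)cc3)s2)cc1`) gives 25%, and compound 1 (`N#C/C(=C\c1ccccc1OS(=O)(=O)c1ccc([N+](=O)[O-])cc1)C(=O)Nc1nnc(-c2cccs2)s1`) gives 23%. Compound 4 (`COc1ccc(Cc2nnc(NC(=O)/C(C#N)=C/c3ccccc3OS(=O)(=O)c3ccc([N+](=O)[O-])cc3)s2)cc1`) is unmeasured and has nitro in place of methoxy on an aromatic carbon. For the measured compounds named here, the only measured step at this place is a number 75 percentage points higher from compound 2 to compound 3 (beyond the scatter), which is large and has methoxy replacing methyl. Compound 1 also carries (4-nitrophenyl)sulfonyl, on a different remainder, and stays at 23%. A large fall beyond the scatter is therefore expected, estimated as a number 60 percentage points lower from compound 3 to compound 4 (beyond the scatter). Compound 4 is estimated at 40%, with an expected range of 12% to 90%.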

Compound 4, percent growth inhibition at one concentration: 51%
The estimate for compound 4 lay 11 percentage points below the measured number; measured number inside the range.
By their numbers in this assay, from the lowest: compounds 1 and 2 (each within the scatter of the next); then compound 4; then compound 3.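

Swapping (4-methoxyphenyl)sulfonyl for (4-nitrophenyl)sulfonyl gives a number 49 percentage points lower from compound 3 to compound 4 (beyond the scatter) and shows that a second replacement of methoxy also loses much of the growth inhibition. Nitro still outperforms methyl at this place, with a number 26 percentage points higher from compound 2 to compound 4 (beyond the scatter) on the same core, so the order here runs methoxy, nitro, methyl. With nitro held constant, the other end of the molecule also counts, with a number 28 percentage points higher from compound 1 to compound 4 (beyond the scatter) when 4-methoxybenzyl replaces thiophen-2-yl.

No available measurement explains these steps. From the compounds shown here alone, whether an amine or a hydroxyl at this place would match methoxy stays open.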